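A few compounds are considered here, and "the series" means these few. Any claim that something is new, unique, unknown or untested is made for them only; others in the source may bear on it.

Compound 3 `COc1ccc(/C=C/C(=O)c2ccc(OC)c3c2OC(C)(C)C=C3)c(F)c1` is the starting point of this step. In a functional assay on HCT-116 cells (Homo sapiens) for antiproliferative activity, read by MTT assay, with a stated time of 24 h (on this read-out lower numbers stand for stronger inhibition and higher numbers for weaker inhibition), compound 3 gives > 10000 nM, which is a limit of the assay and not a number. Compound 1 `COc1cccc(/C=C/C(=O)c2ccc(OC)c3c2OC(C)(C)C=C3)c1` also stops at a limit: in this assay compound 1 gives > 10000 nM. Compound 2 `COc1ccc(C(=O)/C=C/c2cc(OC)c(OC)c(OC)c2)c2c1C=CC(C)(C)O2` is the only one of the three with a number, and in this assay compound 2 gives 7650 nM. Compound 3 thus stands at the limit of > 10000 nM in this assay, at which 2 of the 3 values shown sit, and its place relative to compound 2 cannot be read closer than that.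

Compound 4 `COc1ccc(C(=O)/C=C/c2ccc(F)cc2)c2c1C=CC(C)(C)O2` differs from compound 3 by 4-fluorophenyl in place of 2-fluoro-4-methoxyphenyl on a double-bonded chain carbon bound to a double-bonded chain carbon. Within the data shown here, the one measured step at the same place is a step that the two limits leave unreadable from compound 1 to compound 3, and with both ends at the limit it gives no size to go by. Among the measured compounds shown here, nothing among the measured compounds shows a change at this chain carbon moving the read-out beyond the scatter, so compound 4 is expected to stay close to where compound 3 sits, and a step that the limit leaves unreadable from compound 3 to compound 4 is expected to be no larger than the scatter, in no clear direction. Compound 4 is therefore estimated at 12000 nM, within a range from 3000 nM to 40000 nM, with a real chance that only a limit is reported again.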

Compound 4, half-maximal inhibitory concentration: > 10000 nM
Compound 4 gave a limit, no number; the forecaster's own chance of this, stated with the estimate: 65%; the middle value is on the limit's open side.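

Among these compounds, compound 4 also stops at a limit, and no step among compound 1, compound 3 and compound 4 can be read in this assay. The compounds shown leave open how far each of these three lies from the limit, and whether a change on this chain carbon moves the read-out at all.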